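A few compounds are considered here, and "the series" means these few. Any claim that something is new, unique, unknown or untested is made for them only; others in the source may bear on it.

Compound 3 `CN(c1ccc2cc(NC(=O)CCc3ccc(C(F)(F)F)cc3)ccc2n1)C1CCCC1` stands second highest of the three numbers in a functional assay on HEK293 cells for activation of melanin-concentrating hormone receptor 1 (Rattus norvegicus), read by inositol phosphate accumulation (on this read-out lower numbers stand for an effect already at smaller amounts and higher numbers for an effect only at larger amounts of compound), giving 350 nM. Compound 2 `CC1CCCN1c1ccc2cc(NC(=O)CCc3ccc(C(F)(F)F)cc3)ccc2n1` gives 270 nM, and compound 1 `CN(c1ccc2cc(NC(=O)CCc3ccc(C(F)(F)F)cc3)ccc2n1)C1CCCCC1` gives 1200 nM. Compound 4 `CNC(=O)NC1CCN(c2ccc3cc(NC(=O)CCc4ccc(C(F)(F)F)cc4)ccc3n2)C1` is the next member; the change from compound 3 is 3-((methylcarbamoyl)amino)pyrrolidin-1-yl in place of cyclopentyl(methyl)amino on an aromatic carbon. For the measured compounds named here, two measured steps bear on it. The step of a 1.3-fold higher number from compound 2 to compound 3 (0.11 log units; within the scatter) shows that a 2-methylpyrrolidin-1-yl and a cyclopentyl(methyl)amino give nearly the same number. The step of a 3.4-fold lower number from compound 1 to compound 3 (0.54 log units; beyond the scatter) shows the cyclohexyl to cyclopentyl exchange is modest. Going by the values given here, no measured step covers the methylcarbamoylamino group entering on the pyrrolidine, so uncertainty is wide. The expected step is a 1.4-fold higher number from compound 3 to compound 4 (0.15 log units; within the scatter), likely within the scatter. Compound 4 is estimated at 500 nM, range 150 nM to 2000 nM.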

Compound 4, half-maximal effective concentration: 30 nM
Estimate against measurement, compound 4: 17-fold (1.22 log units) above, outside the stated range (below it).
By their numbers in this assay, from the lowest: compound 4; then compounds 2 and 3 (each within the scatter of the next); then compound 1.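

In this assay, the aromatic carbon next to the ring nitrogen takes 3-((methylcarbamoyl)amino)pyrrolidin-1-yl, with a 12-fold lower number from compound 3 to compound 4 (1.07 log units; beyond the scatter), a 9.0-fold lower number from compound 2 to compound 4 (0.95 log units; beyond the scatter) and a 40-fold lower number from compound 1 to compound 4 (1.60 log units; beyond the scatter), so all three steps to compound 4 lie beyond the scatter. For the compounds shown here, this is the first group to bring in hydrogen-bond donors and a carbonyl, and compound 4 has the lowest number of the four. Nothing measured here explains the gain.

Open, on these data alone, is whether a plain amine, a hydroxyl or an acetamide on the pyrrolidine would give a similar number, or whether the whole methylcarbamoylamino group is needed.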